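Shorter group on the amide nitrogen of compound 1

A few compounds are considered here, and "the series" means these few. Any claim that something is new, unique, unknown or untested is made for them only; others in the source may bear on it.

In a functional assay on CEM13 cells (Homo sapiens) for cytotoxicity, read by MTT assay, with a stated time of 72 h (on this read-out higher numbers stand for weaker inhibition and lower numbers for stronger inhibition), compound 1 `Cc1c(C)c2c(c(C)c1OC(=O)CCC(=O)O)CCC(C)(C(=O)NCC1CC(C)(C)N([O])C1(C)C)O2` gives > 300000 nM, which is a limit. Compound 2 `Cc1c(C)c2c(c(C)c1O)CCC(C)(C(=O)NCC1CC(C)(C)N([O])C1(C)C)O2` gives > 300000 nM, also a limit. Among the compounds with values here, compound 3 `Cc1c(C)c2c(c(C)c1OC(=O)CCC(=O)NCC1CC(C)(C)N([O])C1(C)C)CCC(C)(C(=O)NCC1CC(C)(C)N([O])C1(C)C)O2` gives 107000 nM, the only value that is not a limit. The series therefore stands mostly at the limit of > 300000 nM in this assay, at which 2 of the 3 values shown sit.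

Compound 4 `Cc1c(C)c2c(c(C)c1OC(=O)CCC(=O)O)CCC(C)(C(=O)NC1CC(C)(C)N([O])C1(C)C)O2` changes the core of compound 1 on an amide-type nitrogen: a group of 10 heavy atoms (8 carbon, 1 nitrogen, 1 oxygen; one five-membered non-aromatic ring with 1 hetero atom) in place of a group of 11 heavy atoms (9 carbon, 1 nitrogen, 1 oxygen; one five-membered non-aromatic ring with 1 hetero atom), on an amide-type nitrogen. Within the data shown here, no measured step covers this place. a step that the two limits leave unreadable from compound 1 to compound 2 cannot be sized, while an at least 2.8-fold lower number from compound 1 to compound 3 (0.44 log units; beyond the scatter) is a change on a carbonyl carbon. No step beyond the scatter is therefore expected in this assay, and a further limit is likely. The estimated step is a number no higher from compound 1 to compound 4 (the limit leaves the size open). For compound 4 the expected value is 300000 nM, with an estimated range of 120000 nM to 600000 nM.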

Compound 4, half-maximal inhibitory concentration: 205000 nM
For compound 4 the middle estimate is 1.5-fold (0.17 log units) above the measured one, and the stated range covers the measured number.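

In this assay, within the data shown here, the shorter group on the amide-type nitrogen gives an at least 1.4-fold lower number from compound 1 to compound 4 (0.16 log units; that floor lies within the scatter) and so provides the first readable change at this place, with the (2-carboxyethyl)carbonyl group retained. On these data alone, the value of compound 1 is a limit, so the true size of this step remains open and only its floor is known. The series still rests heavily on limits: the limit of > 300000 nM in this assay, at which 2 of the 4 values shown sit.

As far as these compounds go, it remains open whether a longer chain on the amide-type nitrogen would give a step beyond the scatter. An amine in place of the five-membered ring group is equally untested here.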